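Chloropyridine amide in a weakly antiproliferative series

The compounds below may be only part of what the source reports. "The series", "measured", "known", "first", "only" and "open" are said of these compounds alone.

Two amides built on a shared core have been measured in a functional assay on MCF7 cells (Homo sapiens) for antiproliferative activity, read by MTT assay, with a stated time of 72 h; on this read-out higher numbers stand for weaker inhibition and lower numbers for stronger inhibition. Compound 1 `O=C(Nc1ccc(Cl)c(-c2nnc3c(Cl)cccn23)c1)c1ccccc1Cl` gives 92200 nM in this assay, and compound 2 `O=C(Nc1ccc(Cl)c(-c2nnc3c(Cl)cccn23)c1)c1ccccn1` gives 96400 nM. The only structural difference between them is pyridin-2-yl in place of 2-chlorophenyl on a carbonyl carbon, and the step of a 1.0-fold higher number from compound 1 to compound 2 (0.02 log units; within the scatter) shows that this swap leaves the read-out unchanged. Compound 2 therefore stands together with compound 1, the two numbers indistinguishable within the scatter.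

Compound 3 `O=C(Nc1ccc(Cl)c(-c2nnc3c(Cl)cccn23)c1)c1cccnc1Cl` differs from compound 2 in one place: 2-chloropyridin-3-yl in place of pyridin-2-yl on a carbonyl carbon. Among the compounds with values here, the one step in hand that bears on this change is a 1.0-fold higher number from compound 1 to compound 2 (0.02 log units; within the scatter), where exchanging the whole aryl group on the carbonyl carbon made no difference. Adding a chlorine to the pyridine ring, and moving its point of attachment, is a smaller change than that, so no step beyond the scatter is expected from compound 2 to compound 3. Compound 3 is accordingly estimated at 95000 nM in this assay, with a range from 40000 nM to 220000 nM, that is, an expected step of a 1.0-fold lower number from compound 2 to compound 3 (0.01 log units; within the scatter).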

Compound 3, half-maximal inhibitory concentration: > 100000 nM
Compound 3 ended at the assay's limit; the forecaster's own chance of this, stated with the estimate: 25%; middle value at least 1.0-fold (0.02 log units) away from the limit.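

Compound 3 ends not at a number but at a limit of this assay: the limit of > 100000 nM in this assay, at which 1 of the 3 values shown sits. Set against the two earlier amides, the change gives an at least 1.0-fold higher number from compound 2 to compound 3 (0.01 log units; that floor lies within the scatter), and the wider exchange gives an at least 1.0-fold higher number from compound 1 to compound 3 (0.03 log units; that floor lies within the scatter), so each printed floor lies within the scatter and neither step can be sized beyond it. What compound 3 adds is that a third aryl group on a carbonyl carbon whose other neighbour is an amide-type nitrogen, here 2-chloropyridin-3-yl with its chlorine, brings no stronger inhibition, while any weakening past the limit remains out of sight.

From the compounds shown here alone, all three groups at this position are six-membered aromatic rings, so it remains open whether a group of another kind there, such as an amine, a carboxylic acid or a longer alkyl chain, would bring the number clearly down from this range. Going by these compounds, it is also open whether changes elsewhere on the shared core, rather than on the carbonyl carbon, would shift the read-out at all.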